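A Second Chloro Added to the Core of Compound 3

The source may hold more compounds than are shown below. What is called first, only, known or untested is meant among the compounds shown, and "the series" means these compounds.

Of the compounds shown here, three have been measured in a functional assay on SN12C cells (Homo sapiens) for cytotoxicity, read by sulforhodamine B assay, with a stated time of 48 h; a higher number here means a weaker inhibitor of growth, a lower number a stronger inhibitor of growth. Compound 2 `ClCc1ccccc1Cn1cnc2c(Cl)ncnc21` gives 8710 nM, while compound 1 `ClCc1ccccc1Cn1cnc2c(Cl)nc(Cl)nc21` gives 2040 nM. The change from compound 2 to compound 1 is chloro in place of hydrogen on an aromatic carbon, and it made a step of a 4.3-fold lower number from compound 2 to compound 1 (0.63 log units; beyond the scatter). Compound 3 `ClCc1ccccc1Cn1cnc2ncnc(Cl)c21` gives 8510 nM in this assay; it has the same atoms as compound 2 joined differently, and the difference between the two cores is not broken down here. Compound 4 `ClCc1ccccc1Cn1cnc2nc(Cl)nc(Cl)c21` is not yet measured. It differs from compound 3 by chloro in place of hydrogen on an aromatic carbon, the same change as from compound 2 to compound 1, described around the place in identical words. Resting on that single precedent, the step from compound 3 to compound 4 is expected to be a 3.9-fold lower number from compound 3 to compound 4 (0.59 log units; beyond the scatter). Compound 4 is accordingly estimated at 2200 nM, most likely between 900 nM and 5500 nM.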

Compound 4, concentration for total growth inhibition: 2570 nM
Estimate against measurement, compound 4: 1.2-fold (0.07 log units) below, and the stated range covers the measured number.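

In this assay, the chloro placed between two ring nitrogen atoms produced a 3.3-fold lower number from compound 3 to compound 4 (0.52 log units; beyond the scatter), and the change kept its size when carried from one core to the other: the same change on two cores in this assay, a 4.3-fold lower number (0.63 log units; beyond the scatter) from compound 2 to compound 1 and a 3.3-fold lower number (0.52 log units; beyond the scatter) from compound 3 to compound 4, 1.3-fold (0.11 log units) apart, within the scatter of two such steps

The number therefore falls on both cores shown, and these two cores have the same atoms joined differently. Within the data shown here, this rests on only two pairs in a single cell line, and it shows neither why the chloro has this effect nor whether the step would hold on any other core.

The compounds shown leave open what an amine, a methoxy group or a longer chain would do in place of that chloro. Every compound shown also carries the same chloromethyl group, and the effect of replacing it with a hydroxymethyl group remains open too.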